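Cyclopentyl in Place of Butyl on the Aryl Ether

A few compounds are considered here, and "the series" means these few. Any claim that something is new, unique, unknown or untested is made for them only; others in the source may bear on it.

Three measured compounds share one core. In an assay on cells for antagonist activity at transient receptor potential cation channel subfamily V member 1 (Homo sapiens), read by FLIPR and calcium flux, with a stated time of 6 min (a lower number here means a stronger inhibitor, a higher number a weaker inhibitor), compound 1 `CC(C(=O)NCc1ccc(C(C)(C)C)nc1SCc1ccccc1Cl)c1ccc(NS(C)(=O)=O)c(F)c1` gives 3.8 nM. Compound 2 `CCCOc1cc(C(C)(C)C)ccc1CNC(=O)C(C)c1ccc(NS(C)(=O)=O)c(F)c1` gives 4.4 nM, and compound 3 `CCCCOc1cc(C(C)(C)C)ccc1CNC(=O)C(C)c1ccc(NS(C)(=O)=O)c(F)c1` gives 1.4 nM, the lowest number of the three, with compound 1 nearest and compound 2 furthest. Compound 4 `CC(C(=O)NCc1ccc(C(C)(C)C)cc1OC1CCCC1)c1ccc(NS(C)(=O)=O)c(F)c1` differs from compound 3 by cyclopentyl in place of butyl on an oxygen on an aromatic ring. Within the data shown here, no measured step covers this exchange; the only single-point step, a 3.1-fold lower number from compound 2 to compound 3 (0.50 log units; beyond the scatter), added one carbon to the same chain and is the nearest guide. Since the incoming group is of similar size, the number for compound 4 is expected to stay close to that of compound 3, with the estimated step being a 1.1-fold higher number from compound 3 to compound 4 (0.03 log units; within the scatter). Compound 4 is therefore expected to give about 1.5 nM, within a range of 0.6 nM to 4 nM.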

Compound 4, inhibition constant: 1.8 nM
Compound 4: the middle estimate sits 1.2-fold (0.08 log units) below what was measured, and the stated range covers the measured number.
By their numbers in this assay, from the lowest: compounds 3 and 4 (each within the scatter of the next); then compounds 1 and 2 (each within the scatter of the next).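

In this assay, a ring on this oxygen serves as well as an open chain: cyclopentyl in place of butyl gives a 1.3-fold higher number from compound 3 to compound 4 (0.11 log units; within the scatter), so the closed five-membered ring and the four-carbon chain cannot be told apart here. Compared with the propyl ether, cyclopentyl gives a 2.4-fold lower number from compound 2 to compound 4 (0.39 log units; beyond the scatter), so compound 4 keeps the separation from compound 2 that compound 3 also shows. No evidence is available on why these numbers fall as they do.

The compounds shown leave open whether cyclopropyl or cyclohexyl on the same oxygen would hold the number. From the compounds shown here alone, a branched isobutyl chain there also remains untested by these compounds.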